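The Same Side-Chain Swap Tried on a Second Core

This account rests on a few compounds, and the source may have more. Where it says the series, first, only, none or still open, it means among the compounds named here.

Compound 1 `CC(C)[C@H](NC(=O)CN(c1nc(Cl)nc2[nH]cnc12)C1CC1)C(=O)OCc1ccccc1`: 51.3%
Compound 2 `CSCC[C@H](NC(=O)CN(c1nc(Cl)nc2[nH]cnc12)C1CC1)C(=O)OCc1ccccc1`: 44.6%
Compound 3 `CSCC[C@H](NC(=O)CN(c1ncnc2c1ncn2C1CCCCO1)C1CC1)C(=O)OCc1ccccc1`: 42.7%

Of the compounds shown here, three have been measured in a functional assay on the whole organism (Tail, strain ICR) with Mus musculus as the target, in the tail flick test, with a stated time of 90 min, at a dose of 25 umol/kg by the oral route; a lower number here means a weaker effect, a higher number a stronger effect of the compound at the dose given. Compound 1 and compound 2 share one core and differ in a single side chain; the change is isopropyl in place of 2-(methylsulfanyl)ethyl on a saturated chain carbon bound to an amide-type nitrogen and a carbonyl carbon. This change gave a number 6.7 percentage points higher from compound 2 to compound 1 (within the scatter). Compound 3 carries a different core; compound 2 and compound 3 differ in more than one place, and the difference between the two cores is not broken down here. In this assay compound 3 gives 42.7%, a number that sits within the scatter of both compound 2 and compound 1.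

Compound 4 `CC(C)[C@H](NC(=O)CN(c1ncnc2c1ncn2C1CCCCO1)C1CC1)C(=O)OCc1ccccc1` has not been measured yet. It stands to compound 3 as compound 1 stands to compound 2: the change is isopropyl in place of 2-(methylsulfanyl)ethyl on a saturated chain carbon bound to an amide-type nitrogen and a carbonyl carbon. The place of the change is the same in both pairs, so this is the same change carried out on the second core.

Because a number 6.7 percentage points higher from compound 2 to compound 1 (within the scatter) lay within the scatter, the expected step here is also small: it is estimated at a number 6.3 percentage points higher from compound 3 to compound 4 (within the scatter). The expectation rests on a single earlier instance of the change and on compound 3 giving 42.7%, so it is a loose one. Compound 4 is expected to give about 49% in this assay, estimated to fall between 35% and 63%.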

Compound 4, a percentage reported as activity, at one dose (the size of the read-out at that dose, not a potency): 30.1%
Compound 4: middle estimate off by 18.9 percentage points, on the high side; the whole stated range lies above it.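

In this assay, putting isopropyl in place of 2-(methylsulfanyl)ethyl on the second core gave a number 12.6 percentage points lower from compound 3 to compound 4 (beyond the scatter), which is not what the same swap did on the first core. Set side by side, the two results disagree: the same change on two cores in this assay, a number 6.7 percentage points higher (within the scatter) from compound 2 to compound 1 and a number 12.6 percentage points lower (beyond the scatter) from compound 3 to compound 4, 19.3 percentage points apart, beyond the scatter of two such steps. This shows that, among these four compounds, the effect of this side-chain change cannot simply be carried from one core to the other, and that a result on one core is a poor guide to the result on the other; it does not show why the two cores respond differently, and it rests on just one pair of compounds per core, tested at a single dose and a single time point, which is too little to support a general rule for the series.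

The compounds shown carry only these two side chains, leaving open how a longer chain, or a side chain bearing an amine or a carboxylic acid, would behave on either core. As far as these compounds go, compound 2 and compound 3 differ in more than one place, and which of those differences in the core matters for the change in the side chain also remains open.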